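This account rests on a few compounds, and the source may have more. Where it says the series, first, only, none or still open, it means among the compounds named here.

Compound 1, `O=C(Nc1cccc(-n2cc(-c3ccncc3)c(-c3ccc(Cl)c(O)c3)n2)c1)Nc1ccc(Cl)c(Cl)c1`, and compound 2, `COc1cc(-c2nn(-c3cccc(NC(=O)c4ccc(Cl)c(C(F)(F)F)c4)c3)cc2-c2ccncc2)ccc1Cl`, have both been tested in a functional assay on TK-10 cells (Homo sapiens) for inhibition, read by sulforhodamine B assay, with a stated time of 48 h; a lower number here means that less compound is tolerated, a higher number that more compound is tolerated. In this assay compound 1 gives > 32500 nM, which is a limit of the assay rather than a measured number. Compound 2 likewise gives > 32500 nM, again a limit rather than a number. Every value shown so far therefore sits at the limit of > 32500 nM in this assay, at which 2 of the 2 values shown sit, so compound 2 stands exactly where compound 1 stands, with no number separating them.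

Compound 3, `COc1cc(-c2nn(-c3cccc(NC(=O)Nc4cccc(C(F)(F)F)c4)c3)cc2-c2ccncc2)ccc1Cl`, has not yet been measured. It differs from compound 2 in one place: (3-(trifluoromethyl)phenyl)amino in place of 4-chloro-3-(trifluoromethyl)phenyl on a carbonyl carbon.

Within the data shown here, no measured pair of neighbouring compounds offers a step to lean on, so the size of the change is a matter of expectation only. Given that compound 2 sits at the limit > 32500 nM, compound 3 is expected to move by a number no higher from compound 2 to compound 3 (the limit leaves the size open), that is, by nothing beyond the usual scatter. Compound 3 is thus estimated at 32500 nM, with a plausible range from 12000 nM to 32500 nM.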

Compound 3, concentration lethal to 50% of the cells: > 50000 nM
Compound 3 ended at the assay's limit (the forecaster's own chance of this, stated with the estimate: 75%); middle value at least 1.5-fold (0.18 log units) from the limit.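

Compound 2 and compound 3 both end at limits of this assay rather than at numbers, so no step can be read between them. The compounds shown leave open whether (3-(trifluoromethyl)phenyl)amino in place of 4-chloro-3-(trifluoromethyl)phenyl changes how much compound these cells tolerate.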